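Shortening the Chain and Adding a Hydroxy Group

The source may report more compounds than this note shows. Statements on the series, on what has been measured and on what is new or still open speak of the compounds shown alone.

Compound 1, `CCCCCCCc1cn(C(c2ccccc2)c2cc3cc(Br)ccc3nc2OC)nn1`: 16.6%
Compound 2, `CCCCCCc1cn(C(c2ccccc2)c2cc3cc(Br)ccc3nc2OC)nn1`: 6.08%
Compound 3, `CCCCCc1cn(C(c2ccccc2)c2cc3cc(Br)ccc3nc2OC)nn1`: 5.07%

In an ADME assay on PANC-1 cells (Homo sapiens) for cytotoxicity, read by sulforhodamine B assay, with a stated time of 48 h, tested at 10 uM (a lower number here means less inhibition, a higher number more inhibition at the concentration tested (going by the name of the read-out)), compound 3 stands lowest of the three measured compounds; compound 2 sits within the scatter of it, while compound 1 lies higher, beyond the scatter. Compound 4, `COc1nc2ccc(Br)cc2cc1C(c1ccccc1)n1cc(CCO)nn1`, differs from compound 3 by hydroxy in place of propyl on a saturated chain carbon, two bonds along the chain from an aromatic carbon. The measured steps only shorten the chain: a number 10.5 percentage points lower from compound 1 to compound 2 (beyond the scatter) and a number 11.5 percentage points lower from compound 1 to compound 3 (beyond the scatter) were modest drops, and a number 1 percentage points lower from compound 2 to compound 3 (within the scatter) stayed within the scatter. For the measured compounds named here, no measured step shows what a hydroxy group does here. From these steps a small change, not beyond the scatter, is expected in this assay, namely a number 1.6 percentage points lower from compound 3 to compound 4 (within the scatter). Compound 4 is therefore estimated at 3.5%, within a range of 0% to 12%.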

Compound 4, a percentage reported as inhibition, at one concentration (the size of the read-out at that concentration, not a potency): 19.8%
Compound 4: the middle estimate sits 16.3 percentage points below what was measured, and the stated range ends below it.
By their numbers in this assay, from the lowest: compounds 3 and 2 (each within the scatter of the next); then compounds 1 and 4 (each within the scatter of the next).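

Hydroxy in place of propyl, two bonds along the chain from an aromatic carbon, gives a number 14.7 percentage points higher from compound 3 to compound 4 (beyond the scatter) in this assay and hydroxy in place of butyl gives a number 13.7 percentage points higher from compound 2 to compound 4 (beyond the scatter) as well, so this short chain with a hydroxy group does not share the low numbers of compound 2 and compound 3. Hydroxy in place of pentyl gives a number 3.2 percentage points higher from compound 1 to compound 4 (within the scatter) and so leaves compound 4 level with compound 1, the longest chain shown. No available evidence explains this rise.

As far as these compounds go, whether an amine or a carboxylic acid in place of the hydroxy would give a similar number remains open. So does the effect of a hydroxy group on a longer chain.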